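Replacing the Sulfonyl Group of Compound 2

The source may hold more compounds than are shown below. What is called first, only, known or untested is meant among the compounds shown, and "the series" means these compounds.

Compound 1 (`CC(C)C[C@H](NC(=O)CSc1cc(NS(=O)(=O)c2cccs2)c2ccccc2c1O)B(O)O`) gives 9450 nM
Compound 2 (`Cc1ccc(S(=O)(=O)Nc2cc(SC(C)C(=O)N[C@@H](CC(C)C)B(O)O)c(O)c3ccccc23)cc1`) gives 8610 nM
Compound 3 (`CC(C)C[C@H](NC(=O)C(C)Sc1cc(NS(=O)(=O)c2ccccc2)c2ccccc2c1O)B(O)O`) gives 16500 nM; 11300 nM (2 entries)

In a functional assay on MCF7 cells (Homo sapiens) for antiproliferative activity, read by sulforhodamine B assay, with a stated time of 72 h (a higher number here means a weaker inhibitor, a lower number a stronger inhibitor), compound 2 gives 8610 nM and compound 1 gives 9450 nM, a gap within the scatter. Compound 4 (`CC(C)C[C@H](NC(=O)C(C)Sc1cc(NS(=O)(=O)c2cccs2)c2ccccc2c1O)B(O)O`) has not yet been measured. It differs from compound 2 by one change, thiophen-2-yl in place of 4-methylphenyl on a sulfonyl sulfur. Within the data shown here, no measured pair of compounds shows what a single change does here, so no step beyond the scatter is expected. The expected change is a 1.2-fold higher number from compound 2 to compound 4 (0.06 log units; within the scatter) and should stay small. For compound 4, the estimate is 10000 nM in this assay, with 5000 nM to 20000 nM as the expected range.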

Compound 4, half-maximal inhibitory concentration: 14700 nM
Beside the measured number, compound 4's estimate is 1.5-fold (0.17 log units) below it, within the range that was stated.
By their numbers in this assay, from the lowest: compounds 2, 1 and 4 (each within the scatter of the next).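

Two single changes can now be read in this assay. Thiophen-2-yl in place of 4-methylphenyl on the sulfonyl sulfur gives a 1.7-fold higher number from compound 2 to compound 4 (0.23 log units; within the scatter), and methyl in place of hydrogen on the saturated chain carbon bound to a carbonyl carbon and a sulfur gives a 1.6-fold higher number from compound 1 to compound 4 (0.19 log units; within the scatter). Neither step can be told apart from the scatter, and repeat readings of a single compound also differ: the several entries of compound 3 in this assay, 16500 nM; 11300 nM (2 entries)

Going by these compounds, it remains open whether a sulfonyl group bearing a ring with an amine or a carboxylic acid would move the number beyond the scatter. The same question stands for a longer chain in place of that methyl.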